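Cyclopropyl in Place of a Silicon Group on the Alkyne

The source may report more compounds than this note shows. Statements on the series, on what has been measured and on what is new or still open speak of the compounds shown alone.

Compound 1, `C[Si](C)(C)C#Cc1c[nH]c(=O)[nH]c1=O`: 268000 nM
Compound 2, `CCCCC#Cc1cn([C@@H]2O[C@H](CO)[C@@H](O)[C@H]2O)c(=O)[nH]c1=O`: 83200 nM
Compound 3, `O=c1[nH]c(=O)n([C@@H]2O[C@H](CO)[C@@H](O)[C@H]2O)cc1C#CC(O)c1ccccc1`: 34200 nM

In an ADME assay on A549 cells (Homo sapiens) for cytotoxicity, read by MTT assay (a higher number here means that more compound is tolerated, a lower number that less compound is tolerated), compound 1 stands highest of the three numbers, with compound 2 nearest and compound 3 furthest below it. Compound 4, `O=c1[nH]cc(C#CC2CC2)c(=O)[nH]1`, differs from compound 1 in one place: a group of 3 heavy atoms (3 carbon; one three-membered non-aromatic ring of carbon only) in place of a group of 4 heavy atoms (3 carbon, 1 silicon; no ring), on a triple-bonded carbon. Among the measured compounds shown here, the only measured step that also changes the group on the triple-bonded carbon is a 2.4-fold lower number from compound 2 to compound 3 (0.39 log units; beyond the scatter), a modest shift, though it occurred in a pair that carries a sugar which compound 1 and compound 4 lack. That step suggests swapping the alkyne substituent moves the number only a little, and in the direction of less compound tolerated. The silicon-containing group and cyclopropyl are both small and bring no donors or acceptors, so a step near the edge of the scatter, slightly downward, is expected: a 1.4-fold lower number from compound 1 to compound 4 (0.15 log units; within the scatter). Compound 4 is therefore estimated at 190000 nM, within a range from 70000 nM to 500000 nM.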

Compound 4, half-maximal cytotoxic concentration: 251000 nM
For compound 4 the middle estimate is 1.3-fold (0.12 log units) below the measured one; low and high end bracket the measured number.
By their numbers in this assay, from the lowest: compound 3; then compound 2; then compounds 4 and 1 (each within the scatter of the next).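

At this position, on a triple-bonded carbon of the sugar-free core, cyclopropyl in place of the silicon group gives a 1.1-fold lower number from compound 1 to compound 4 (0.03 log units; within the scatter) in this assay and so leaves the tolerated concentration indistinguishable from that of compound 1. Among the compounds shown here, this is the first step at this position read without a sugar, whereas the only earlier step, a 2.4-fold lower number from compound 2 to compound 3 (0.39 log units; beyond the scatter) in a sugar-bearing pair, lay beyond the scatter. No measurement shown explains why these two groups read alike.

From the compounds shown here alone, an amine, a carboxylic acid or a longer chain on this triple-bonded carbon of the sugar-free core remains open, so how far this tolerance extends to other groups is unknown. No pair shown differs only in the sugar, so the effect of the sugar alone in this assay cannot be read.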